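A Dichlorophenyl Swap on Compound 1

This account rests on a few compounds, and the source may have more. Where it says the series, first, only, none or still open, it means among the compounds named here.

For the measured compounds named here, in a functional assay on NIH3T3 cells (Mus musculus) (a higher number here means that more compound is needed for the effect, a lower number that less compound is needed), compound 1 (`Cn1cncc1C(OCc1ccc(C#N)cc1-c1ccc(F)c(Cl)c1)c1ccc(C#N)nc1`) gives 46 nM, the highest of the three numbers measured so far. Compound 2 (`Cn1cncc1C(OCc1ccc(C#N)cc1)c1ccc(C#N)c(-c2cccc3cccnc23)c1`) gives 3.7 nM and compound 3 (`Cn1cncc1C(OCc1ccc(C#N)nc1-c1ccc(OC(F)(F)F)cc1)c1ccc(C#N)cc1`) gives 4 nM. Both numbers lie below that of compound 1 by a margin beyond the scatter, and they lie within the scatter of each other.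

Compound 4 (`Cn1cncc1C(OCc1ccc(C#N)cc1-c1cc(Cl)cc(Cl)c1)c1ccc(C#N)nc1`) keeps the core of compound 1 and changes one group: 3,5-dichlorophenyl in place of 3-chloro-4-fluorophenyl on an aromatic carbon. A 3,5-dichlorophenyl stands in place of 3-chloro-4-fluorophenyl, on an aromatic carbon ortho to a large group and meta to a cyano group. Going by the values given here, neither compound 2 nor compound 3 differs from compound 1 in one place only, so no measured step speaks to this swap directly. In this assay, only a small move towards a lower number is expected, with nothing beyond the scatter. The estimated step of a 1.5-fold lower number from compound 1 to compound 4 (0.19 log units; within the scatter) is expected to stay within the scatter. The estimated value for compound 4 is 30 nM, with an expected range from 10 nM to 100 nM.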

Compound 4, half-maximal effective concentration: 3.5 nM
The estimate for compound 4 lay 8.6-fold (0.93 log units) above the measured number; the measured number lies below the stated range.
By their numbers in this assay, from the lowest: compounds 4, 2 and 3 (each within the scatter of the next); then compound 1.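

In this assay, for the compounds shown here, the swap to 3,5-dichlorophenyl gives a 13-fold lower number from compound 1 to compound 4 (1.12 log units; beyond the scatter) and is the first one-place step that can be read here. It shows that this aromatic carbon, ortho to a large group and meta to a cyano group, does not treat these two halogenated phenyl groups alike, although both have the same count of heavy atoms, no hydrogen-bond donors or acceptors and no net charge. Nothing shown gives a reason for the size of this step.

On these data alone, it stays open which part of the change carries the step, the fluorine leaving or the second chlorine entering, and a 3-chlorophenyl or a 3,5-difluorophenyl in this place would separate the two. As far as these compounds go, whether a 3,5-dimethylphenyl would fit the same trend also remains open.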